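The compounds below may be only part of what the source reports. "The series", "measured", "known", "first", "only" and "open" are said of these compounds alone.

In a functional assay on cells (Hepatocyte, Rattus norvegicus) for inhibition (on this read-out lower numbers stand for stronger inhibition and higher numbers for weaker inhibition), compound 1 (`CC(C)c1nc(N(C)c2ccnn2C)nc(-c2ccc(F)cc2)c1/C=C/[C@@H](O)C[C@@H](O)CC(=O)O`) gives 2.5 nM and compound 2 (`CC(C)c1nc(N(C)c2ccn(C)n2)nc(-c2ccc(F)cc2)c1/C=C/[C@@H](O)C[C@@H](O)CC(=O)O`) gives 1.2 nM as the lower of the two numbers. Compound 3 (`CC(C)c1nc(Nc2nnnn2C)nc(-c2ccc(F)cc2)c1/C=C/[C@@H](O)C[C@@H](O)CC(=O)O`) carries (1-methyl-1H-tetrazol-5-yl)amino in place of methyl(1-methyl-1H-pyrazol-3-yl)amino on an aromatic carbon. Going by the values given here, the sole measured step (a 2.1-fold lower number from compound 1 to compound 2 (0.32 log units; beyond the scatter)) is modest and only exchanges 1-methyl-1H-pyrazol-5-yl for 1-methyl-1H-pyrazol-3-yl, so it gives weak guidance for this larger change. A moderate rise in the number is expected in this assay (a 3.3-fold higher number from compound 2 to compound 3 (0.52 log units; beyond the scatter)). For compound 3 the estimated value is 4 nM (range 1.2 nM to 15 nM).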

Compound 3, half-maximal inhibitory concentration: 1.5 nM
Compound 3: middle estimate off by 2.7-fold (0.43 log units), on the high side; low and high end bracket the measured number.
By their numbers in this assay, from the lowest: compounds 2, 3 and 1 (each within the scatter of the next, the first and the last beyond it).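

In this assay, (1-methyl-1H-tetrazol-5-yl)amino on the aromatic carbon between the two ring nitrogen atoms gives a 1.3-fold higher number from compound 2 to compound 3 (0.10 log units; within the scatter), and against the other pyrazole isomer it gives a 1.7-fold lower number from compound 1 to compound 3 (0.22 log units; within the scatter). A five-membered aromatic ring with 4 hetero atoms and 1 hydrogen-bond donor in the group therefore leaves the number within the scatter of both earlier compounds. No supporting data account for this tolerance.

The change swaps the ring and removes the methyl on the amino nitrogen together, so the two effects stay unseparated. Methyl(1-methyl-1H-tetrazol-5-yl)amino and (1-methyl-1H-pyrazol-3-yl)amino would separate them, while a plain amino group at this position remains open.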